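The source may report more compounds than this note shows. Statements on the series, on what has been measured and on what is new or still open speak of the compounds shown alone.

Of the compounds shown here, three with a shared core have been tested in a functional assay on Z-138 cells (Homo sapiens) for antiproliferative activity, with a stated time of 72 h; a higher number here means a weaker inhibitor, a lower number a stronger inhibitor. Compound 1 `CCCC#Cc1cc([C@@H]2O[C@H](CO)[C@@H](O)[C@H]2O)n2ncnc(N)c12`, with propyl on a triple-bonded carbon, gives 20 nM. Compound 2 `CCCCC#Cc1cc([C@@H]2O[C@H](CO)[C@@H](O)[C@H]2O)n2ncnc(N)c12`, with butyl in that place, gives 200 nM. Compound 3 `Nc1ncnn2c([C@@H]3O[C@H](CO)[C@@H](O)[C@H]3O)cc(C#Cc3ccc(F)cc3)c12`, with 4-fluorophenyl there, gives 89000 nM, the highest number of the three and so the weakest inhibitor among them.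

Compound 4 `Nc1ncnn2c([C@@H]3O[C@H](CO)[C@@H](O)[C@H]3O)cc(C#Cc3ccccc3)c12` has not yet been measured. It differs from compound 3 by a single change, hydrogen in place of fluoro on an aromatic carbon, para to a large group.

Among the measured compounds shown here, no measured step makes this exact change, so the evidence is indirect. The steps that introduce 4-fluorophenyl are both large: a 4500-fold higher number from compound 1 to compound 3 (3.65 log units; beyond the scatter) and a 450-fold higher number from compound 2 to compound 3 (2.65 log units; beyond the scatter). The step between the two chains, a 10-fold higher number from compound 1 to compound 2 (1.00 log units; beyond the scatter), is modest, and it shows only that a single methyl can move the number in this series. Compound 4 keeps the phenyl ring on the triple bond, so it is expected to stay on the weak side of the gap shown by a 450-fold higher number from compound 2 to compound 3 (2.65 log units; beyond the scatter). The expected change is small, a 1.8-fold lower number from compound 3 to compound 4 (0.25 log units; within the scatter), and leans towards a lower number. For compound 4 the estimated value in this assay is 50000 nM, with an expected range from 6000 nM to 150000 nM.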

Compound 4, half-maximal inhibitory concentration: 41400 nM
Compound 4: the middle estimate sits 1.2-fold (0.08 log units) above what was measured; measured number inside the range.
By their numbers in this assay, from the lowest: compound 1; then compound 2; then compound 4; then compound 3.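

Taking the fluoro off the aromatic carbon, para to a large group, gives a 2.1-fold lower number from compound 3 to compound 4 (0.33 log units; beyond the scatter) in this assay and this modest step lies beyond the scatter, so this position does respond to the change from fluoro to hydrogen. The response is small beside what remains when the ring carries no fluoro at all: the chains still stand well clear of the phenyl ring, with a 210-fold higher number from compound 2 to compound 4 (2.32 log units; beyond the scatter) and a 2100-fold higher number from compound 1 to compound 4 (3.32 log units; beyond the scatter) both large, so most of the gap first seen with 4-fluorophenyl stays with phenyl itself and only a small part of it goes with the fluoro. Nothing in the available data explains either the modest step or the large ones.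

The compounds shown leave open whether another group on that same aromatic carbon, such as chloro, methoxy or an amine, would move the number further in either direction. They also leave open whether a saturated ring such as cyclohexyl or a shorter chain such as ethyl on the triple-bonded carbon would stand nearer the chains or nearer phenyl.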